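The source may report more compounds than this note shows. Statements on the series, on what has been measured and on what is new or still open speak of the compounds shown alone.

- Compound 1 `CC(=O)N1CCC(C(=O)N2CCC(N3CCN(C(=O)c4cc(-c5ccc(F)cc5)nc(-c5ccc6[nH]ccc6c5)c4)CC3)CC2)CC1`: 44.3 10^-6 cm/s
- Compound 2 `CC(=O)N1CCC(C(=O)N2CCC(N3CCN(C(=O)c4cc(-c5cccc(C)c5)nc(-c5ccc6[nH]ccc6c5)c4)CC3)CC2)CC1`: 28.1 10^-6 cm/s

In an ADME assay for permeability, using PAMPA (a lower number here means that the compound crosses the layer more slowly, a higher number that the compound crosses the layer faster), compound 2 gives 28.1 10^-6 cm/s, which lies within the scatter of compound 1. Compound 3 `COc1ccc(-c2cc(C(=O)N3CCN(C4CCN(C(=O)C5CCN(C(C)=O)CC5)CC4)CC3)cc(-c3ccc4[nH]ccc4c3)n2)cc1` differs from compound 2 by carrying 4-methoxyphenyl in place of 3-methylphenyl on an aromatic carbon, next to the ring nitrogen (4-methoxyphenyl in place of 3-methylphenyl on an aromatic carbon). Among the compounds with values here, only one measured step bears on this change: 3-methylphenyl in place of 4-fluorophenyl, a 1.6-fold lower number from compound 1 to compound 2 (0.20 log units; within the scatter). Within the data shown here, with one small step as the only guide, no change beyond the scatter is expected. The expected step is a 1.1-fold higher number from compound 2 to compound 3 (0.03 log units; within the scatter). For compound 3 the estimate is 30 10^-6 cm/s, with an expected range of 14 10^-6 cm/s to 60 10^-6 cm/s.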

Compound 3, apparent permeability: 21.5 10^-6 cm/s
Estimate against measurement, compound 3: 1.4-fold (0.14 log units) above; measured number inside the range.
By their numbers in this assay, from the lowest: compounds 3, 2 and 1 (each within the scatter of the next, the first and the last beyond it).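

In this assay, 4-methoxyphenyl in place of 3-methylphenyl, on the aromatic carbon next to the ring nitrogen, gives a 1.3-fold lower number from compound 2 to compound 3 (0.12 log units; within the scatter) and so shows no clear effect. Methoxy in place of fluoro gives a 2.1-fold lower number from compound 1 to compound 3 (0.31 log units; beyond the scatter) and is the first step at this position to pass the scatter, though only modestly. Nothing measured here gives a reason for this step. Still open is how this assay would read with an amine or a carboxylic acid on this phenyl ring, since all three groups shown carry only a small neutral substituent.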